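A few compounds are considered here, and "the series" means these few. Any claim that something is new, unique, unknown or untested is made for them only; others in the source may bear on it.

Compound 3 `COc1ccc(Oc2ccc(C(C)C)cc2-c2ccsc2S(=O)(=O)NCCNC(=O)Nc2cc(Cl)cc(Cl)c2)cc1OC` is one of three compounds with a number in a functional assay on HL-60 cells (Homo sapiens) for inhibition, read by CCK-8 assay, with a stated time of 48 h; on this read-out higher numbers stand for weaker inhibition and lower numbers for stronger inhibition. In this assay compound 3 gives 6500 nM, the second highest of the three numbers. Its nearest neighbour is compound 2 `O=[N+]([O-])c1ccc(NC(=S)N2CCN(S(=O)(=O)c3sccc3-c3ccccc3Oc3ccc(O)c(O)c3)CC2)cc1`, which in this assay gives 5300 nM, a gap that lies within the scatter of repeated measurements. The furthest is compound 1 `O=C(NCCNS(=O)(=O)c1ccc(-c2ccccc2Oc2ccc(O)c(O)c2)s1)Nc1cc(Cl)cc(Cl)c1`, which in this assay gives 10400 nM, a gap also within the scatter. The three measured values therefore cannot be placed in any firm order. Compound 4 `CC(C)c1ccc(Oc2ccc(O)c(O)c2)c(-c2ccsc2S(=O)(=O)NCCNC(=O)Nc2cc(Cl)cc(Cl)c2)c1` has not yet been measured. It differs from compound 3 in one place: 3,4-dihydroxyphenyl in place of 3,4-dimethoxyphenyl on an oxygen on an aromatic ring. Compounds 1 and 2 both carry 3,4-dihydroxyphenyl on that oxygen and their values sit within the scatter of compound 3, so no step beyond the scatter is expected in either direction. The step that this estimate means is a 1.1-fold lower number from compound 3 to compound 4 (0.03 log units; within the scatter) and is expected to stay within the scatter. Compound 4 is estimated at 6000 nM in this assay, with a range from 2000 nM to 18000 nM.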

Compound 4, half-maximal inhibitory concentration: 6500 nM
For compound 4 the middle estimate is 1.1-fold (0.03 log units) below the measured one, and the stated range covers the measured number.
By their numbers in this assay, from the lowest: compounds 2, 3, 4 and 1 (each within the scatter of the next).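

In this assay, replacing 3,4-dimethoxyphenyl with 3,4-dihydroxyphenyl on an oxygen on an aromatic ring gives no change at the digits printed from compound 3 to compound 4 (within the scatter). This is the first pair shown that differs in this one place, so the change can be read directly, and the read-out does not separate the two groups here even though only the entering group has hydrogen-bond donors. The data shown offer no explanation for this result.

Going by these compounds, it remains open whether a phenyl without substituents, a 3-hydroxyphenyl, or a phenyl carrying an amine or a carboxylic acid on this oxygen would move the number beyond the scatter. On these data alone, it is also open whether the same exchange would give a similar result on the cores of compound 1 and compound 2.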